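Deacetylation across two cyclopentenone cores in cytotoxicity

This account rests on a few compounds, and the source may have more. Where it says the series, first, only, none or still open, it means among the compounds named here.

Compound 1 `COc1cc(C2=C(c3cc(C)c(OC)c(C)c3)C(O)CC2=O)cc(OC)c1OC` and compound 2 `COc1cc(C2=C(c3cc(C)c(OC)c(C)c3)C(OC(C)=O)CC2=O)cc(OC)c1OC` share a core; compound 3 `CC(=O)OC1C/C(=N/O)C(c2ccccc2)=C1c1ccccc1` and compound 4 `O/N=C1/CC(O)C(c2ccccc2)=C1c1ccccc1` share another, and the difference between the two cores is not broken down here. In an ADME assay on KB cells (Homo sapiens) for cytotoxicity, read by MTT assay, with a stated time of 72 h (a higher number here means a weaker inhibitor, a lower number a stronger inhibitor), compound 2 gives only a limit, > 100 ug/mL. Compound 1 likewise gives only a limit, > 100 ug/mL. Compound 3 gives 9 ug/mL. The step that the two limits leave unreadable from compound 2 to compound 1 is hydrogen in place of acetyl on an oxygen on a saturated carbon; since both values sit at the limit of > 100 ug/mL in this assay, at which 2 of the 3 values shown sit, its size is unreadable. The step from compound 3 to compound 4 is the same change, (hydrogen in place of acetyl on an oxygen on a saturated carbon), at the same kind of place. Among the compounds with values here, no readable step guides it, so the expected step of a 1.7-fold higher number from compound 3 to compound 4 (0.22 log units; within the scatter) is small, with wide uncertainty, because the only comparable pair gives (the limit of > 100 ug/mL in this assay, at which 2 of the 3 values shown sit). Compound 4 is estimated at 15 ug/mL, within 4 ug/mL to 60 ug/mL.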

Compound 4, half-maximal inhibitory concentration: > 100 ug/mL
Compound 4 ended at the assay's limit; the forecaster's own chance of this, stated with the estimate: 15%; middle value at least 6.6-fold (0.82 log units) from the limit.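

In this assay, acetoxy to hydroxy on the core of compound 3 gives an at least 11-fold higher number from compound 3 to compound 4 (1.04 log units; beyond the scatter). Going by these compounds, compound 4 gives > 100 ug/mL, which is a limit, so the exact size of this step remains unknown. The same change from compound 2 to compound 1 cannot be read, so nothing shows whether the step carries from one core to the other: the limit of > 100 ug/mL in this assay, at which 3 of the 4 values shown sit.

Only acetoxy and hydroxy appear at this place among the compounds shown, so the effect of an amine or a longer ester chain there remains open on both cores. The difference between the two cores also remains unresolved, with no single-place comparison linking them.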